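A bromo group added on the amide side

The compounds below may be only part of what the source reports. "The series", "measured", "known", "first", "only" and "open" are said of these compounds alone.

Compound 1 `CCc1ccc(NC(=O)C2CCN(C/C=C/c3ccccc3)CC2)cc1`: 11600 nM
Compound 2 `O=C(Nc1cccc(F)c1)C1CCN(C/C=C/c2ccccc2)CC1`: 23300 nM

Both compounds were measured in a functional assay on MGC-803 cells (Homo sapiens) for inhibition, read by MTT assay, with a stated time of 72 h; on this read-out lower numbers stand for stronger inhibition and higher numbers for weaker inhibition. Among the measured compounds shown here, compound 2, at 23300 nM, stands within the scatter of compound 1, the only other compound measured, so neither can be ranked over the other. Compound 3 `O=C(Nc1ccc(F)c(Br)c1)C1CCN(C/C=C/c2ccccc2)CC1` has not yet been measured. It carries 3-bromo-4-fluorophenyl in place of 3-fluorophenyl on an amide-type nitrogen. For the measured compounds named here, one measured step bears on this change, and it also concerns the group on that nitrogen: a 2.0-fold higher number from compound 1 to compound 2 (0.30 log units; within the scatter). Going by the values given here, with only that step to go on, no shift beyond the scatter is expected, and the direction remains open. The estimated change is a 1.4-fold lower number from compound 2 to compound 3 (0.14 log units; within the scatter) and it is expected to stay small. In this assay compound 3 is estimated at 17000 nM, with an expected range from 6000 nM to 45000 nM.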

Compound 3, half-maximal inhibitory concentration: 9270 nM
The estimate for compound 3 lay 1.8-fold (0.26 log units) above the measured number, within the range that was stated.
By their numbers in this assay, from the lowest: compounds 3, 1 and 2 (each within the scatter of the next, the first and the last beyond it).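

In this assay, a change on the amide-type nitrogen now gives a step beyond the scatter: a 2.5-fold lower number from compound 2 to compound 3 (0.40 log units; beyond the scatter), modest in size, with 3-bromo-4-fluorophenyl in place of 3-fluorophenyl. The same group in place of 4-ethylphenyl gives a 1.3-fold lower number from compound 1 to compound 3 (0.10 log units; within the scatter), so compound 1 and compound 3 cannot be ranked, and the three aryl groups shown here differ by no more than a modest step. No measurement offered here accounts for that step.

The compounds shown leave open whether a bromo group without the added fluorine would give the same step, and whether an amine or a carboxylic acid on that phenyl ring would move the number further. From the compounds shown here alone, the rest of the shared core stays the same throughout, so what changes there would do also remains open.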